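A few compounds are considered here, and "the series" means these few. Any claim that something is new, unique, unknown or untested is made for them only; others in the source may bear on it.

Working notes on the series. Within the data shown here, compound 1 `O=C1O/C(=C\Cn2cc(-c3ccc(Br)cc3)nn2)C(OCc2ccccc2)=C1OCc1ccccc1` and compound 2 `CCCCCCCCCCc1cn(C[C@H](O)[C@H]2OC(=O)C(OCc3ccccc3)=C2OCc2ccccc2)nn1` share the core and differ in several places at once, so no single-point step between them is available. In a functional assay on HeLa cells (Homo sapiens) for antiproliferative activity, read by MTT assay, with a stated time of 72 h (on this read-out higher numbers stand for weaker inhibition and lower numbers for stronger inhibition), compound 1 gives 24300 nM. In this assay compound 2 gives 22900 nM, the lower of the two numbers, but the gap to compound 1 lies within the scatter of this read-out, so neither compound can be placed ahead of the other.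

Compound 3 `O=C1O[C@H]([C@@H](O)Cn2ccnn2)C(OCc2ccccc2)=C1OCc1ccccc1` is the next point and is not yet measured. It differs from compound 2 in one place: hydrogen in place of decyl on an aromatic carbon. Among the measured compounds shown here, no measured step of this kind exists here, so the expectation rests on compound 2 alone. A modest step upward is expected, a 1.7-fold higher number from compound 2 to compound 3 (0.24 log units; within the scatter), that is a somewhat weaker inhibition than compound 2. For compound 3 the estimate is 40000 nM, with a range from 15000 nM to 120000 nM.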

Compound 3, half-maximal inhibitory concentration: > 100000 nM
Compound 3 gave a limit, no number (the forecaster's own chance of this, stated with the estimate: 25%); middle value at least 2.5-fold (0.39 log units) away from the limit.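

Hydrogen in place of decyl on an aromatic carbon of the five-membered aromatic ring with 3 nitrogen gives, in this assay, an at least 4.3-fold higher number from compound 2 to compound 3 (0.64 log units; beyond the scatter). Among these compounds, this is the first single-point step, and it shows that the group on this carbon matters for the read-out, which compounds 1 and 2 could not show. The value of compound 3 is a limit and not a number, so the step gives a minimum size only: the limit of > 100000 nM in this assay, at which 1 of the 3 values shown sits.

One pair cannot show whether the read-out follows chain length or simply needs a large group at this carbon. A shorter chain such as hexyl, a longer chain such as dodecyl, or a decyl chain ending in an amine or a carboxylic acid would each test this, and the compounds shown leave all of these open.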